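Methyl to tert-butyl on the benzyl arm

A few compounds are considered here, and "the series" means these few. Any claim that something is new, unique, unknown or untested is made for them only; others in the source may bear on it.

In an assay on isolated protein for inhibition of protein deacetylase HDAC6 (Homo sapiens), read by fluorescence, with stated times of 10 min and 2 h (a higher number here means a weaker inhibitor, a lower number a stronger inhibitor), compound 1 `CC1(c2ccccc2)NC(=O)N(Cc2ccc(C(=O)NO)cc2)C1=O` gives 74.9 nM. Compound 2 `O=C(NO)c1ccc(CN2C(=O)NC(Cc3ccc(Cl)cc3)(c3ccccc3)C2=O)cc1` gives 54 nM, and compound 3 `Cc1ccc(CC2(c3ccccc3)NC(=O)N(Cc3ccc(C(=O)NO)cc3)C2=O)cc1` gives 82.4 nM, the highest of the three numbers, though every gap stays within the scatter: a 1.1-fold higher number from compound 1 to compound 3 (0.04 log units; within the scatter) and a 1.5-fold higher number from compound 2 to compound 3 (0.18 log units; within the scatter). Compound 4 `CC(C)(C)c1ccc(CC2(c3ccccc3)NC(=O)N(Cc3ccc(C(=O)NO)cc3)C2=O)cc1` differs from compound 3 by tert-butyl in place of methyl on an aromatic carbon. Placing the whole 4-methylphenyl group, from compound 1 to compound 3, moved nothing beyond the scatter, and neither did exchanging chloro for methyl, from compound 2 to compound 3, so a bulkier group on that same aromatic carbon is expected to change little. The estimated step in this assay is a 1.0-fold higher number from compound 3 to compound 4 (0.01 log units; within the scatter). Compound 4 is therefore expected to give 85 nM, with a range from 40 nM to 180 nM.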

Compound 4, half-maximal inhibitory concentration: 115 nM
Compound 4: the middle estimate sits 1.4-fold (0.13 log units) below what was measured; the measured number falls inside the stated range.
By their numbers in this assay, from the lowest: compounds 2, 1, 3 and 4 (each within the scatter of the next, the first and the last beyond it).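

Swapping methyl for tert-butyl on this aromatic carbon gives a 1.4-fold higher number from compound 3 to compound 4 (0.14 log units; within the scatter), and adding the whole 4-(tert-butyl)phenyl group gives a 1.5-fold higher number from compound 1 to compound 4 (0.19 log units; within the scatter), so even this larger group leaves the number within the scatter of both compounds. The first gap beyond the scatter in this small set appears on exchanging chloro for tert-butyl, a modest 2.1-fold higher number from compound 2 to compound 4 (0.33 log units; beyond the scatter). Nothing available here explains that gap. Going by these compounds, whether an amine or a carboxylic acid on this same aromatic carbon would keep the number in this range remains open.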